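This account rests on a few compounds, and the source may have more. Where it says the series, first, only, none or still open, it means among the compounds named here.

Measured compounds:
compound 1, `COc1cc(-c2cc(/C=C/C(=O)c3ccc(N)cc3)[nH]n2)cc(OC)c1OC`, gives 1660 nM
compound 2, `COc1ccc(C(=O)/C=C/c2cc(-c3cc(OC)c(OC)c(OC)c3)n[nH]2)cc1OC`, gives 1340 nM
compound 3, `COc1ccc(-c2cc(/C=C/C(=O)c3ccc(N)cc3)[nH]n2)cc1OC`, gives 2530 nM

All three compounds were tested in a functional assay on MDA-MB-435 cells (Homo sapiens) for inhibition, read by sulforhodamine B assay, with a stated time of 48 h; on this read-out lower numbers stand for stronger inhibition of growth and higher numbers for weaker inhibition of growth. The three values lie close together, and none of the gaps between them is beyond the usual scatter of repeated measurements, so no order among them can be read from the numbers.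

From compound 3 to compound 1 the structures differ by methoxy in place of hydrogen on an aromatic carbon, and this gives a 1.5-fold lower number from compound 3 to compound 1 (0.18 log units; within the scatter). From compound 1 to compound 2 the change is a different one, and it gives a 1.2-fold lower number from compound 1 to compound 2 (0.09 log units; within the scatter). Compound 2 and compound 3 differ in several places at once, and the difference between their cores is not broken down here.

The unmeasured compound 4, `COc1cc(C(=O)/C=C/c2cc(-c3cc(OC)c(OC)c(OC)c3)n[nH]2)cc(OC)c1OC`, is reached from compound 2 by methoxy in place of hydrogen on an aromatic carbon. The surroundings of this change are the same as those of the change from compound 3 to compound 1, so it is the same change in a different core. Because the earlier one gave a 1.5-fold lower number from compound 3 to compound 1 (0.18 log units; within the scatter), a step of similar size is expected here, namely a 1.3-fold lower number from compound 2 to compound 4 (0.13 log units; within the scatter). On this basis compound 4 is estimated to give 1000 nM in this assay, expected to fall between 450 nM and 2400 nM.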

Compound 4, concentration for 50% growth inhibition: 1490 nM
Compound 4: middle estimate off by 1.5-fold (0.17 log units), on the low side, within the range that was stated.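

In this assay, methoxy in place of hydrogen on an aromatic carbon gives a 1.1-fold higher number from compound 2 to compound 4 (0.05 log units; within the scatter). Set beside the same change on the other core, this step cannot be told apart from the earlier one: the same change on two cores in this assay, a 1.5-fold lower number (0.18 log units; within the scatter) from compound 3 to compound 1 and a 1.1-fold higher number (0.05 log units; within the scatter) from compound 2 to compound 4, 1.7-fold (0.23 log units) apart, within the scatter of two such steps. Among the compounds shown here, this shows that nothing in these two pairs speaks against carrying the change from one core to the other, but it does not show that the change has an effect of a shared size, since neither step stands clear of the scatter and the two cores together give only two readings of it.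

The compounds shown leave open whether a group other than methoxy in this place, such as a hydroxyl, a chlorine atom or a longer ether chain like ethoxy, would give a step that stands clear of the scatter in this assay. Also open, going by these compounds, is how an amide or a carboxylic acid in place of the amine of the 4-aminophenyl group would read, and whether the methoxy change would behave the same way on a core beyond these two.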